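Hydrazone series: from a hydroxyphenyl to a dichlorophenyl

A few compounds are considered here, and "the series" means these few. Any claim that something is new, unique, unknown or untested is made for them only; others in the source may bear on it.

Three hydrazones built on one shared core have been measured in a functional assay on MDA-MB-435 cells (Homo sapiens) for inhibition, read by sulforhodamine B assay, with a stated time of 48 h; a higher number here means a weaker inhibitor of growth, a lower number a stronger inhibitor of growth. Compound 1 `O=C(Cc1csc2nc(-c3ccc(Br)cc3)cn12)N/N=C/c1ccccc1` gives 12000 nM. Compound 2 `O=C(Cc1csc2nc(-c3ccc(Br)cc3)cn12)N/N=C/c1ccccc1O` gives 3310 nM in this assay, and compound 3 `O=C(Cc1csc2nc(-c3ccc(Br)cc3)cn12)N/N=C/c1ccc(O)cc1` gives 6310 nM. Compound 2 has the lowest number of the three; its gap to compound 3 is within the scatter, while the step of a 3.6-fold lower number from compound 1 to compound 2 (0.56 log units; beyond the scatter) lies beyond it.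

Compound 4 `O=C(Cc1csc2nc(-c3ccc(Br)cc3)cn12)N/N=C/c1ccc(Cl)cc1Cl` has not yet been measured. It differs from compound 2 in one place: 2,4-dichlorophenyl in place of 2-hydroxyphenyl on a carbon with a double bond to nitrogen. Within the data shown here, two measured steps bear on this change. The hydroxy that sets compound 2 apart from compound 1 brought a 3.6-fold lower number from compound 1 to compound 2 (0.56 log units; beyond the scatter), and the hydroxy of compound 3 brought a 1.9-fold lower number from compound 1 to compound 3 (0.28 log units; within the scatter). Compound 4 carries no hydroxy at all, so the gain seen in compound 2 is expected to be lost and the number is expected to move back toward that of compound 1. Among the measured compounds shown here, no measured compound carries chlorine on this ring, so the two chlorines have no precedent in this set. Compound 4 is therefore expected to give a higher number than compound 2, estimated at 9000 nM with a range of 3000 nM to 30000 nM, an expected step of a 2.7-fold higher number from compound 2 to compound 4 (0.43 log units; beyond the scatter).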

Compound 4, concentration for 50% growth inhibition: 31600 nM
Estimate against measurement, compound 4: 3.5-fold (0.55 log units) below; the measured number lies above the stated range.
By their numbers in this assay, from the lowest: compounds 2, 3 and 1 (each within the scatter of the next, the first and the last beyond it); then compound 4.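

In this assay, the change to 2,4-dichlorophenyl on the carbon with a double bond to nitrogen does more than return the number to that of the plain phenyl: there is a 2.6-fold higher number from compound 1 to compound 4 (0.42 log units; beyond the scatter), so compound 4 ends up past the compound with no substituent on this ring. The steps from the two hydroxy compounds are larger, with a 9.5-fold higher number from compound 2 to compound 4 (0.98 log units; beyond the scatter) and a 5.0-fold higher number from compound 3 to compound 4 (0.70 log units; beyond the scatter), which makes compound 4 the weakest inhibitor of growth of the four and shows that this position, where until now only hydroxy groups had been seen lowering the number, can also move it upward. No measurement shown gives a reason for this rise, so the result stands here as an observation only.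

The compounds shown leave open how much of the step belongs to the loss of the hydroxy and how much to the arrival of the two chlorines, since both happen in one change. A ring carrying a single chlorine, a hydroxy together with a chlorine, or a methoxy or an amine in place of the hydroxy would each bear on that question.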